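Swapping the dimethoxyphenyl of compound 1 for fluorophenyl

A few compounds are considered here, and "the series" means these few. Any claim that something is new, unique, unknown or untested is made for them only; others in the source may bear on it.

Measured compounds:
Compound 1, `COc1ccc(C2OC(c3cc(OC)c(OC)c(OC)c3)=NN2C(C)=O)c(OC)c1`: -3.1%
Compound 2, `COc1cc(/C=N/NC(=O)c2cc(OC)c(OC)c(OC)c2)cc(OC)c1OC`: 22.9%

In a functional assay on BGC-823 cells (Homo sapiens) for antiproliferative activity, read by MTT assay, tested at 5 uM (on this read-out higher numbers stand for a stronger effect at the one concentration tested and lower numbers for a weaker effect), compound 1 gives -3.1%, the lowest of the two numbers, sitting near no effect. Compound 2 gives 22.9% in this assay, a number higher than that of compound 1 by a gap beyond the usual scatter; the two differ in several places at once, so this gap cannot be tied to one change.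

Compound 3, `COc1cc(C2=NN(C(C)=O)C(c3ccccc3F)O2)cc(OC)c1OC`, has not been measured. It differs from compound 1 in a single place: 2-fluorophenyl in place of 2,4-dimethoxyphenyl on a saturated ring carbon. For the measured compounds named here, no step between measured compounds isolates a change of this kind, so the expectation rests on compound 1 alone. With compound 1 at -3.1%, the change is expected to shift the number only a little, upward if at all, and not clearly beyond the scatter. Compound 3 is therefore expected to give about 6% in this assay, between -10% and 28%, which amounts to an expected step of a number 9.1 percentage points higher from compound 1 to compound 3 (within the scatter).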

Compound 3, a percentage reported as inhibition, at one concentration (the size of the read-out at that concentration, not a potency): 32.8%
Estimate against measurement, compound 3: 26.8 percentage points below; the measured number lies above the stated range.
By their numbers in this assay, from the lowest: compound 1; then compounds 2 and 3 (each within the scatter of the next).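

In this assay, the saturated ring carbon of the core of compound 1 proves sensitive to the group it carries: 2-fluorophenyl in place of 2,4-dimethoxyphenyl gives a number 35.9 percentage points higher from compound 1 to compound 3 (beyond the scatter), a large step. The swap changes several things at once, since the entering group has fewer heavy atoms and no hydrogen-bond acceptors, while the leaving group has 2, and a single step cannot separate these differences. Nothing available explains the rise.

The compounds shown leave open whether the gain follows the fluorine itself or the loss of the two methoxy groups, a question that a plain phenyl or a 2-chlorophenyl on that carbon would address. Also open, as far as these compounds go, is whether the step would hold if a propanoyl group replaced the acetyl group on the ring nitrogen.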